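Aryl amine swap on the shared core

The source may report more compounds than this note shows. Statements on the series, on what has been measured and on what is new or still open speak of the compounds shown alone.

Among the measured compounds shown here, compound 1 `O=C1C(Nc2ccc(Br)cc2)=CC(=O)c2c1nc1n2[C@H]2OC[C@@H](O)[C@H]2OC1` carries the only number in a functional assay on MGC-803 cells (Homo sapiens) for inhibition, read by sulforhodamine B assay; a higher number here means a weaker inhibitor, a lower number a stronger inhibitor; in that assay compound 1 gives 2020 nM. Compound 2 `CCCN(CCC)C1=CC(=O)c2nc3n(c2C1=O)[C@H]1OC[C@@H](O)[C@H]1OC3` reaches the limit of > 16000 nM in this assay, at which 1 of the 2 values shown sits, and gives > 16000 nM, a limit of the assay rather than a number. The move to compound 3 `COc1cccc(NC2=CC(=O)c3c(nc4n3[C@H]3OC[C@@H](O)[C@H]3OC4)C2=O)c1` is 3-methoxyphenyl in place of 4-bromophenyl on an amine nitrogen. For the measured compounds named here, no measured step covers this pair, so the size of the step is open; a shift of about the usual scatter in either direction seems as likely as none, with weaker inhibition slightly favoured. Compound 3 is expected to give 3000 nM, between 1000 nM and 9000 nM. That corresponds to an expected step of a 1.5-fold higher number from compound 1 to compound 3 (0.17 log units; within the scatter).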

Compound 3, half-maximal inhibitory concentration: 1790 nM
Estimate against measurement, compound 3: 1.7-fold (0.22 log units) above, and the stated range covers the measured number.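

The swap of 3-methoxyphenyl for 4-bromophenyl on the amine nitrogen gives a 1.1-fold lower number from compound 1 to compound 3 (0.05 log units; within the scatter) in this assay, so this aryl position tolerates this change without a shift beyond the scatter. Both the substituent and its ring position change in this one step, so neither can be read alone. Nothing measured here gives a cause for this step. Still open, from the compounds shown here alone, is how an unsubstituted phenyl would read on this nitrogen. Going by these compounds, a pyridine ring or a benzyl group there is equally open.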